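Swapping the amine on a dithiocarbamate chromone

The source may hold more compounds than are shown below. What is called first, only, known or untested is meant among the compounds shown, and "the series" means these compounds.

Compound 1: `O=c1c(Cl)c(CSC(=S)N2CCOCC2)oc2ccccc12`, 19200 nM
Compound 2: `COc1ccc2oc(CSC(=S)N(C(C)C)C(C)C)cc(=O)c2c1`, 19100 nM

Of the compounds shown here, two have been measured so far in a functional assay on LM7 cells (Homo sapiens) for antiproliferative activity, read by MTT assay, with a stated time of 72 h; a lower number here means a stronger inhibitor, a higher number a weaker inhibitor. Compound 1 gives 19200 nM in this assay, and compound 2 gives 19100 nM. The two numbers sit at the same level: the gap between them is well inside the scatter of repeated measurements, so neither compound can be called the stronger one. Both are weak inhibitors on this cell line.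

Compound 3, `COc1ccc2oc(CSC(=S)N3CCCCC3)cc(=O)c2c1`, has not been measured yet. It differs from compound 2 at a single place: piperidin-1-yl in place of diisopropylamino on a thiocarbonyl carbon. Within the data shown here, no measured pair in this set shows what such a change does, so the size of the step in this assay is unknown; with only one structural change and two nearly equal starting points, the expectation is for no step beyond the scatter, in either direction.

On that basis the value for compound 3 in this assay is estimated at 18000 nM, with a range from 7000 nM to 45000 nM. This estimate means a step of a 1.1-fold lower number from compound 2 to compound 3 (0.03 log units; within the scatter) that is expected to stay within the usual scatter.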

Compound 3, half-maximal inhibitory concentration: 5000 nM
For compound 3 the middle estimate is 3.6-fold (0.56 log units) above the measured one; measured number below the stated range.
By their numbers in this assay, from the lowest: compound 3; then compounds 2 and 1 (each within the scatter of the next).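

In this assay, the group on the thiocarbonyl carbon turns out to matter: with the rest of the molecule unchanged, piperidin-1-yl in place of diisopropylamino gives a 3.8-fold lower number from compound 2 to compound 3 (0.58 log units; beyond the scatter), a modest step, but one beyond the scatter. Among these compounds, no earlier pair spoke to this position, and this pair shows that a single change in the amine part can move activity on these cells, with the ring of piperidin-1-yl giving the lower number here and the open, branched diisopropylamino the higher one. No measurement shown here bears on why this happens, and the finding rests on this one pair.

As far as these compounds go, it remains open whether any ring on this carbon would give the same result or only piperidin-1-yl, and pyrrolidin-1-yl or dimethylamino at the same place would help to separate those two readings. Steps involving compound 1 cannot be read, since it differs from the others in more than one place, so it is also unknown whether the same swap would have the same effect on a different core.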